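The source may report more compounds than this note shows. Statements on the series, on what has been measured and on what is new or still open speak of the compounds shown alone.

In a functional assay on HeLa cells (Homo sapiens) for antiproliferative activity, read by MTT assay, with a stated time of 48 h (on this read-out lower numbers stand for stronger inhibition and higher numbers for weaker inhibition), three compounds built on a shared core have been measured so far: compound 1 `Cn1cc(-c2cnc3ccc(NC(=O)C4CC4)nc3c2)cn1`, compound 2 `CCNc1ccc2ncc(-c3cnn(C)c3)cc2n1` and compound 3 `Cn1cc(-c2cnc3ccc(NS(=O)(=O)c4ccc(C(F)(F)F)cc4)nc3c2)cn1`. Compound 1 gives > 50000 nM, which is a limit of the assay and not a number. Compound 2 gives > 50000 nM, which is also a limit. Compound 3 gives > 50000 nM, and this too is a limit. Compound 3 therefore has no rank among its relatives, and the whole set shows (the limit of > 50000 nM in this assay, at which 3 of the 3 values shown sit).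

Compound 4 `Cn1cc(-c2cnc3ccc(NS(=O)(=O)c4cccs4)nc3c2)cn1` differs from compound 3 in one place, with thiophen-2-yl in place of 4-(trifluoromethyl)phenyl on a sulfonyl sulfur. Among the compounds with values here, the only measured step between two compounds that differ in one place is a step that the two limits leave unreadable from compound 1 to compound 2. That step involves a different group and its size cannot be read, so it offers no guide to size or direction here.

The expectation therefore rests on the limit reached by all three measured compounds. No change beyond the usual scatter is expected, and the estimated step is a number no higher from compound 3 to compound 4 (the limit leaves the size open). Compound 4 is estimated at 50000 nM, with an expected range of 15000 nM to 100000 nM.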

Compound 4, half-maximal inhibitory concentration: 38400 nM
Compound 4: middle estimate off by 1.3-fold (0.11 log units), on the high side; low and high end bracket the measured number.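

In this assay, within the data shown here, compound 4 gives 38400 nM, the only value in the set that is a number and not a limit, so a change on the sulfonyl sulfur, here thiophen-2-yl in place of 4-(trifluoromethyl)phenyl, has brought a reading inside the range of the assay. The comparisons give an at least 1.3-fold lower number from compound 3 to compound 4 (0.11 log units; that floor lies within the scatter), an at least 1.3-fold lower number from compound 2 to compound 4 (0.11 log units; that floor lies within the scatter) and an at least 1.3-fold lower number from compound 1 to compound 4 (0.11 log units; that floor lies within the scatter); each is only a floor, so none of them establishes a real gain in strength. The set as a whole therefore remains weak in this test, with most of its values stuck at one end of the scale: the limit of > 50000 nM in this assay, at which 3 of the 4 values shown sit.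

A plain phenyl, a furan-2-yl or a methyl on the same sulfonyl sulfur would be needed to separate the part played by the sulfur-containing ring from the loss of the trifluoromethyl group. The compounds shown also leave open whether any group at this position can move the number beyond the scatter.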